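Compound 3 to compound 4: replacing the 2-bromophenyl group

This account rests on a few compounds, and the source may have more. Where it says the series, first, only, none or still open, it means among the compounds named here.

In an ADME assay on HEK293 cells (Homo sapiens) for cytotoxicity, read by MTT assay, with a stated time of 24 h (a higher number here means a weaker inhibitor, a lower number a stronger inhibitor), compound 3 `CN(C)CCCNc1nc2cc([N+](=O)[O-])ccc2nc1NCc1ccccc1Br` gives 51.9 ug/mL, the highest of the three numbers. Compound 1 `CN(C)CCCNc1nc2cc([N+](=O)[O-])ccc2nc1NCc1ccc(C(F)(F)F)cc1` gives 5.66 ug/mL, and compound 2 `CN(C)CCCNc1nc2cc([N+](=O)[O-])ccc2nc1NCc1ccccc1` gives 2.74 ug/mL. Compound 4 `CN(C)CCCNc1nc2cc([N+](=O)[O-])ccc2nc1NCc1cccc(C(F)(F)F)c1` differs from compound 3 by 3-(trifluoromethyl)phenyl in place of 2-bromophenyl on a saturated chain carbon bound to a nitrogen on an aromatic ring.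

Within the data shown here, three measured steps bear on this change. The large 19-fold higher number from compound 2 to compound 3 (1.28 log units; beyond the scatter) comes with bromo in place of hydrogen, and the modest 9.2-fold higher number from compound 1 to compound 3 (0.96 log units; beyond the scatter) comes with 2-bromophenyl in place of 4-(trifluoromethyl)phenyl. Hydrogen in place of trifluoromethyl gives only the modest 2.1-fold lower number from compound 1 to compound 2 (0.32 log units; beyond the scatter). Among the measured compounds shown here, no measured compound carries 3-(trifluoromethyl)phenyl, so the estimate is loose.

A modest to large drop is expected, as an 8.0-fold lower number from compound 3 to compound 4 (0.90 log units; beyond the scatter). The estimated value for compound 4 is 6.5 ug/mL, with an expected range of 2.5 ug/mL to 20 ug/mL.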

Compound 4, half-maximal inhibitory concentration: 7.99 ug/mL
Estimate against measurement, compound 4: 1.2-fold (0.09 log units) below; the range from low to high includes it.
By their numbers in this assay, from the lowest: compound 2; then compounds 1 and 4 (each within the scatter of the next); then compound 3.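

In this assay, trifluoromethyl does not bring the high number of compound 3 with it: a 6.5-fold lower number from compound 3 to compound 4 (0.81 log units; beyond the scatter) comes with 3-(trifluoromethyl)phenyl in place of 2-bromophenyl. With 3-(trifluoromethyl)phenyl in place of 4-(trifluoromethyl)phenyl, a 1.4-fold higher number from compound 1 to compound 4 (0.15 log units; within the scatter) leaves the two compounds unordered, while a 2.9-fold higher number from compound 2 to compound 4 (0.46 log units; beyond the scatter) comes with trifluoromethyl in place of hydrogen. Nothing measured here accounts for these steps.

Open, as far as these compounds go, is whether 2-(trifluoromethyl)phenyl or 3-bromophenyl would read like compound 3 or like compound 4. Also open, from the compounds shown here alone, is how an amine or a carboxylic acid on the phenyl ring would read.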